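The source may hold more compounds than are shown below. What is called first, only, known or untested is meant among the compounds shown, and "the series" means these compounds.

Measured in a functional assay on HCT-116 cells (Homo sapiens) for inhibition, read by MTT assay, with a stated time of 48 h; on this read-out higher numbers stand for weaker inhibition and lower numbers for stronger inhibition:
Compound 1 `COc1ccc(-n2c(S)nnc2-c2cc(OC)c(OC)c(OC)c2)cc1`: > 60000 nM
Compound 2 `COc1ccc(-n2c(SC)nnc2-c2cc(OC)c(OC)c(OC)c2)cc1`: > 60000 nM
Compound 3 `COc1cc(-c2nnc(SC)n2-c2ccc(N(C)C)cc2)cc(OC)c1OC`: > 60000 nM

Each of these entries is a limit of the assay and not a number. In this assay compound 3 gives > 60000 nM, which is a limit, so no strength of inhibition can be read for it. Within the data shown here, the whole series so far stands in one place: the limit of > 60000 nM in this assay, at which 3 of the 3 values shown sit.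

The next compound is compound 4 `COc1cc(-c2nnc(SCC(=O)c3ccccc3)n2-c2ccc(N(C)C)cc2)cc(OC)c1OC`. The change is benzoyl in place of hydrogen on a saturated chain carbon bound to a sulfur: benzoyl takes the place of a hydrogen on a saturated chain carbon bound to a sulfur, so methylsulfanyl becomes (benzoylmethyl)sulfanyl.

Among the measured compounds shown here, two measured steps bear on this change, and only weakly. The closer one, made on a sulfur, is a step that the two limits leave unreadable from compound 1 to compound 2. The other is a step that the two limits leave unreadable from compound 2 to compound 3. Neither gives a size that can be carried over, so the expectation rests on little. Compound 4 may well end at the limit too, and any readable number would mean stronger inhibition than has been seen so far.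

The expected change is an at least 2.0-fold lower number from compound 3 to compound 4 (0.30 log units; that floor lies within the scatter), a modest one towards stronger inhibition. For compound 4 the estimate is 30000 nM, with an expected range from 5000 nM to 60000 nM.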

Compound 4, half-maximal inhibitory concentration: 42500 nM
Beside the measured number, compound 4's estimate is 1.4-fold (0.15 log units) below it; the measured number falls inside the stated range.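

Compound 4 is the first compound shown in this assay to give a readable number, and it alone stands apart from the rest of the series: the limit of > 60000 nM in this assay, at which 3 of the 4 values shown sit. So the saturated chain carbon bound to a sulfur is a place where a change can bring this series off its limit, and the change that does so here turns methylsulfanyl into (benzoylmethyl)sulfanyl, giving an at least 1.4-fold lower number from compound 3 to compound 4 (0.14 log units; that floor lies within the scatter). Among these compounds, compound 3 holds only a limit, so this step gives a floor and not a true size, and the earlier steps cannot be read at all.

The compounds shown do not tell whether the carbonyl or the aromatic ring of benzoyl goes with the readable number, and a benzyl group, a carboxylic acid or an amine at the end of the same chain on the sulfur would help to separate these parts. They also leave open whether benzoyl at this place would give a readable number on compound 2, which carries methoxy where compound 4 carries dimethylamino.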